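The source may hold more compounds than are shown below. What is called first, only, known or untested is meant among the compounds shown, and "the series" means these compounds.

Working notes on the series. Compound 2 `CCCCCc1ccc(Nc2nc3nonc3nc2O)cc1` carries a pentyl group on the aromatic carbon where compound 1 `Oc1nc2nonc2nc1Nc1ccc(OCc2ccccc2)cc1` carries benzyloxy; the rest of the shared core is the same. In an assay on mitochondria from L6 cells (Rattus norvegicus) for activation, with a stated time of 90 min (a lower number here means that less compound is needed, a higher number that more compound is needed for the effect), compound 1 gives 2400 nM and, in this assay, compound 2 gives 2400 nM. Going by the values given here, the one step measured so far, no change at the digits printed from compound 1 to compound 2 (within the scatter), leaves the read-out where it was. Compound 2 therefore stands level with compound 1 at the digits shown; its nearest neighbour is compound 1, with no change between them beyond the scatter.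

Compound 3 `Oc1nc2nonc2nc1Nc1ccc(C(F)(F)F)cc1` is not yet measured. Its change from compound 2 is trifluoromethyl in place of pentyl on an aromatic carbon. Among the compounds with values here, the only step that bears on this position is the exchange of benzyloxy for pentyl, which gave no change in this assay. Within the data shown here, two rather different groups at this carbon left the value unmoved, so the expectation for compound 3 is a step of a 1.3-fold higher number from compound 2 to compound 3 (0.10 log units; within the scatter) within the scatter, with a wider band of uncertainty than the one measured step itself. The estimate for compound 3 in this assay is 3000 nM, expected to fall between 1000 nM and 9000 nM.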

Compound 3, half-maximal effective concentration: 10400 nM
Estimate against measurement, compound 3: 3.5-fold (0.54 log units) below; measured number above the stated range.
By their numbers in this assay, from the lowest: compounds 1 and 2 (each within the scatter of the next); then compound 3.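

In this assay, the group on this aromatic carbon does matter: trifluoromethyl in place of pentyl gives a 4.3-fold higher number from compound 2 to compound 3 (0.64 log units; beyond the scatter), and trifluoromethyl in place of benzyloxy gives a 4.3-fold higher number from compound 1 to compound 3 (0.64 log units; beyond the scatter). The earlier pair showed only that pentyl and benzyloxy could not be told apart, so that flat reading holds for those two groups and does not extend to trifluoromethyl. Heavy-atom count does not by itself account for the gap, as pentyl has 5 heavy atoms and trifluoromethyl 4, and no measurement at hand explains the step.

The compounds shown leave open whether the higher number is particular to trifluoromethyl or would also come with other groups at this carbon, such as methyl, a chlorine atom, an amine or a carboxylic acid. They also leave open whether a longer chain than pentyl would stay level with compound 2 or move away from it, and so how far the level shared by the pentyl and benzyloxy compounds extends.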